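A few compounds are considered here, and "the series" means these few. Any claim that something is new, unique, unknown or untested is made for them only; others in the source may bear on it.

Compound 1 `COc1ccc(-c2cn3ccnc3c(-c3ccc4ncn(C5CCCCC5)c4c3)n2)cc1` is the reference point of this small set. Going by the values given here, in a functional assay on K562 cells (Homo sapiens) for inhibition, read by sulforhodamine B assay, with a stated time of 48 h, tested at 10 uM (a higher number here means more inhibition at the concentration tested (going by the name of the read-out), a lower number less inhibition), compound 1 gives 92%, the highest of the three numbers so far. Compound 2 `COc1ccccc1-c1cn2ccnc2c(-c2ccc3ncn(C4CCCCC4)c3c2)n1` gives 22.6% in this assay, and compound 3 `c1csc(-c2cn3ccnc3c(-c3ccc4ncn(C5CCCCC5)c4c3)n2)c1` gives 27%. Both departures from compound 1 were steep: a number 69.4 percentage points lower from compound 1 to compound 2 (beyond the scatter) and a number 65 percentage points lower from compound 1 to compound 3 (beyond the scatter), while the pair of lower compounds sits close together, a number 4.4 percentage points higher from compound 2 to compound 3 (within the scatter). Compound 4 `FC(F)(F)c1cccc(-c2cn3ccnc3c(-c3ccc4ncn(C5CCCCC5)c4c3)n2)c1` has not yet been measured in this assay. The change from compound 1 is 3-(trifluoromethyl)phenyl in place of 4-methoxyphenyl on an aromatic carbon. The two measured steps from compound 1 bear on it, since each replaced the 4-methoxyphenyl with another aromatic group and each cost a large share of the inhibition. A further drop is therefore expected, though the new group is neither of the two already tried and the size is uncertain. For compound 4 the estimate in this assay is 40%, with a range from 10% to 85%. That corresponds to an expected step of a number 52 percentage points lower from compound 1 to compound 4 (beyond the scatter).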

Compound 4, a percentage reported as inhibition, at one concentration (the size of the read-out at that concentration, not a potency): 21.5%
Compound 4: the middle estimate sits 18.5 percentage points above what was measured; low and high end bracket the measured number.
By their numbers in this assay, from the lowest: compounds 4, 2 and 3 (each within the scatter of the next); then compound 1.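

The 3-(trifluoromethyl)phenyl group is a third aromatic replacement at this position, and in this assay it too loses most of the inhibition, a number 70.5 percentage points lower from compound 1 to compound 4 (beyond the scatter). It carries no oxygen and no hydrogen-bond acceptor, yet it lands level with the two earlier replacements, a number 5.5 percentage points lower from compound 3 to compound 4 (within the scatter) and a number 1.1 percentage points lower from compound 2 to compound 4 (within the scatter), so among the compounds shown only the 4-methoxyphenyl group gives high inhibition. Nothing available explains this loss or the level reached by the three replacements.

The compounds shown leave open whether the high value depends on the methoxy group itself or on the whole 4-methoxyphenyl arrangement. They also leave open how a plain phenyl, or a phenyl ring carrying an amine or a carboxylic acid, would read at this position.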